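The source may hold more compounds than are shown below. What is called first, only, known or untested is meant among the compounds shown, and "the series" means these compounds.

Measured so far in a functional assay on isolated protein for inhibition of Glucose-dependent insulinotropic receptor (Homo sapiens), read by HTRF and cAMP accumulation; on this read-out lower numbers stand for an effect already at smaller amounts and higher numbers for an effect only at larger amounts of compound:

Compound 1 `Cc1nc(S(C)(=O)=O)ccc1Oc1ncnc(OC2CCN(C(=O)OC(C)(C)CF)CC2)c1F` gives 19.9 nM.
Compound 2 `CCC(F)(F)C(=O)N1CCC(Oc2ncnc(Oc3ccc(S(C)(=O)=O)nc3C)c2F)CC1` gives 17.4 nM.
Compound 3 `Cc1nc(S(C)(=O)=O)ccc1Oc1ncnc(OC2CCN(C(=O)C3CCCC3)CC2)c1F` gives 72.8 nM.

Compound 1 stands second highest of these three numbers. Its nearest neighbour is compound 2, with a 1.1-fold lower number from compound 1 to compound 2 (0.06 log units; within the scatter); its furthest is compound 3, with a 3.7-fold higher number from compound 1 to compound 3 (0.56 log units; beyond the scatter). All three share the same core and differ only in the group attached to the carbonyl carbon at the far end of the molecule.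

Compound 4 `Cc1nc(S(C)(=O)=O)ccc1Oc1ncnc(OC2CCN(C(=O)C3(C)CC3)CC2)c1F` keeps that core and changes the same spot: a group of 4 heavy atoms (4 carbon; one three-membered non-aromatic ring of carbon only) in place of a group of 6 heavy atoms (4 carbon, 1 oxygen, 1 fluorine; no ring), on a carbonyl carbon. For the measured compounds named here, two measured steps bear on this. The step of a 3.7-fold higher number from compound 1 to compound 3 (0.56 log units; beyond the scatter) shows that putting a carbon ring in place of the chain of compound 1 on this carbonyl carbon costs something, and a 4.2-fold higher number from compound 2 to compound 3 (0.62 log units; beyond the scatter) repeats that pattern from a different chain. Going by the values given here, the ring entering in compound 4 is smaller than the cyclopentyl of compound 3, and no measured compound shows what such a small ring does here, so a weaker version of that loss is the only guide. The expected result is therefore a modest move to a higher number, a 2.0-fold higher number from compound 1 to compound 4 (0.30 log units; within the scatter), with compound 4 estimated at 40 nM and a plausible range of 15 nM to 110 nM.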

Compound 4, half-maximal effective concentration: 761 nM
Compound 4: middle estimate off by 19-fold (1.28 log units), on the low side, outside the stated range (above it).
By their numbers in this assay, from the lowest: compounds 2 and 1 (each within the scatter of the next); then compound 3; then compound 4.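

In this assay this carbonyl position proves far less forgiving than the first three compounds suggested, as placing 1-methylcyclopropyl here brings a 38-fold higher number from compound 1 to compound 4 (1.58 log units; beyond the scatter) and a 44-fold higher number from compound 2 to compound 4 (1.64 log units; beyond the scatter) when set against the two open chains. The comparison between the two rings adds the most. The step of a 10-fold higher number from compound 3 to compound 4 (1.02 log units; beyond the scatter) shows that having a carbon-only ring on this carbonyl carbon does not by itself fix the level of the effect: cyclopentyl and 1-methylcyclopropyl end up far apart, and the smaller ring carries the higher number. Nothing measured here speaks to the cause, so the size of this loss stands without an explanation.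

On these data alone, whether the loss follows the size of the ring or the methyl group on it stays open, and a plain cyclopropyl, a cyclobutyl or a cyclohexyl on this carbonyl carbon would help to separate the two. As far as these compounds go, it is also open how far a longer chain carrying fluorine, or an unfluorinated propyl chain, would fall from the open chains of compound 1 and compound 2.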